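Amide variation on the shared core: methoxy in place of amino

A few compounds are considered here, and "the series" means these few. Any claim that something is new, unique, unknown or untested is made for them only; others in the source may bear on it.

Measured compounds:
compound 1, `CN(C)CCNc1cc2c(cn1)cc(NC(=O)c1ccc(N)cc1)c(=O)n2C` — 20400 nM
compound 2, `CN(C)CCNc1cc2c(cn1)cc(NC(=O)c1cc3ccccc3s1)c(=O)n2C` — 3570 nM
compound 3, `CN(C)CCNc1cc2c(cn1)cc(NC(=O)c1ccc(Cl)cc1)c(=O)n2C` — 1640 nM

In a functional assay on MDA-MB-468 cells (Homo sapiens) for antiproliferative activity, read by MTT assay, with a stated time of 48 h (a lower number here means a stronger inhibitor, a higher number a weaker inhibitor), compound 1 stands as the weakest of the three measured compounds; its number is the highest, and both other compounds lie beyond the scatter from it. The nearest is compound 2, reached by a 5.7-fold lower number from compound 1 to compound 2 (0.76 log units; beyond the scatter); the furthest is compound 3, reached by a 12-fold lower number from compound 1 to compound 3 (1.09 log units; beyond the scatter). Between those two, a 2.2-fold lower number from compound 2 to compound 3 (0.34 log units; beyond the scatter).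

Compound 4, `COc1ccc(C(=O)Nc2cc3cnc(NCCN(C)C)cc3n(C)c2=O)cc1`, is the next entry in the series. Relative to compound 1 the change is methoxy in place of amino on an aromatic carbon.

For the measured compounds named here, two measured steps bear on this. The step from compound 1 to compound 3 changes the same aromatic carbon, with a large gain. The step from compound 1 to compound 2 replaces the whole 4-aminophenyl group and gives a more modest gain. Both point the same way: removing the amino group from that position has lowered the number each time. Since the methoxy group is a different replacement than chloro, the size of the step is expected to fall between the two measured gains rather than match the larger one, so in this assay the expectation for compound 4 is a lower number than compound 1, beyond the scatter, as a 4.1-fold lower number from compound 1 to compound 4 (0.61 log units; beyond the scatter). The estimate for compound 4 is 5000 nM, within a range of 2000 nM to 15000 nM.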

Compound 4, half-maximal inhibitory concentration: 15700 nM
Compound 4: middle estimate off by 3.1-fold (0.50 log units), on the low side; measured number outside the range, above it.
By their numbers in this assay, from the lowest: compound 3; then compound 2; then compounds 4 and 1 (each within the scatter of the next).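

In this assay, for the compounds shown here, losing the amino group from this aromatic carbon does not by itself bring the gain that the earlier steps suggested: methoxy and amino are not separated here (a 1.3-fold lower number from compound 1 to compound 4 (0.11 log units; within the scatter)), which leaves the two compounds level within the scatter. The effect at this place depends on the incoming group, as a swap confined to this one carbon, para to a large group, shows a clear loss on going from chloro to methoxy (a 9.6-fold higher number from compound 3 to compound 4 (0.98 log units; beyond the scatter)). The 4-methoxyphenyl amide also falls short of the 1-benzothiophen-2-yl amide (a 4.4-fold higher number from compound 2 to compound 4 (0.64 log units; beyond the scatter)), so the gain of compound 2 cannot be read as a general result of removing the amino group.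

As far as these compounds go, whether the gain belongs to chloro alone or extends to other groups on this carbon remains open, and fluoro, bromo, methyl, trifluoromethyl or a plain hydrogen at the same place would test this. Going by these compounds alone, nothing measured so far accounts for the gap between chloro and methoxy at this position.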